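The source may hold more compounds than are shown below. What is called first, only, known or untested is meant among the compounds shown, and "the series" means these compounds.

In a physicochemical assay for lipophilicity, at pH 7.4 (a higher number here means a more lipophilic compound, a lower number a more polar compound), compound 1 `Cc1cc(NC(=O)NCCCC[C@@H](Nc2cc(C)c(F)c(C)c2)C(=O)NO)ccc1F` gives < 3, which is a limit and not a number. Compound 2 `Cc1ccc(CNCCCC[C@@H](Nc2cc(C)c(F)c(C)c2)C(=O)NO)cc1` gives < 3, also only a limit. Compound 2 therefore stands at the limit of < 3 in this assay, at which 2 of the 2 values shown sit, and no exact position can be given. Compound 3 `Cc1cc(N[C@H](CCCCNCCCc2ccc(F)cc2)C(=O)NO)cc(C)c1F` differs from it by 2-(4-fluorophenyl)ethyl in place of 4-methylphenyl on a saturated chain carbon bound to an amine nitrogen, with 2-(4-fluorophenyl)ethyl in place of 4-methylphenyl on a saturated chain carbon bound to an amine nitrogen. For the measured compounds named here, no measured step is available for scale, so no change beyond the scatter is expected in this assay. The estimated step is a step that the limit leaves unreadable from compound 2 to compound 3. For compound 3, the expected value is 2.8, with an estimated range of 2.2 to 3.3.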

Compound 3, distribution coefficient: < 3
Compound 3: only a limit was reported (the forecaster's own chance of this, stated with the estimate: 60%); the middle value does not contradict the limit.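

For the compounds shown here, compound 2 and compound 3 each give only a limit in this assay, so no step between them can be read: the limit of < 3 in this assay, at which 3 of the 3 values shown sit. From the compounds shown here alone, the exact positions of compound 1, compound 2 and compound 3 in this assay remain open, as does the size of any change with 2-(4-fluorophenyl)ethyl in place of 4-methylphenyl.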